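From phenyl to pyridin-2-yl beside the ethyl amide

The source may hold more compounds than are shown below. What is called first, only, known or untested is meant among the compounds shown, and "the series" means these compounds.

In an ADME assay on microsomes from liver (Homo sapiens) for pharmacokinetics, using NADPH, with a stated time of 30 min, tested at 1 uM (a higher number here means faster removal of the compound, a lower number slower removal), compound 3 `CCNC(=O)c1c(-c2ccccc2)c([C@H](C)Nc2ncnc(N)c2C#N)nc2ccc(F)cc12` gives 22 mL.min-1.g-1, the lower of the two actual numbers. Compound 1 `C[C@H](Nc1ncnc(N)c1C#N)c1nc2ccc(F)cc2c(-c2ccccn2)c1-c1ccccn1` gives 47 mL.min-1.g-1, a gap just beyond the scatter. Compound 2 `CNC(=O)c1c(-c2ccccc2)c([C@H](C)Nc2ncnc(N)c2C#N)nc2ccc(F)cc12` is reported only as a limit, < 14 mL.min-1.g-1.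

Compound 4 `CCNC(=O)c1c(-c2ccccn2)c([C@H](C)Nc2ncnc(N)c2C#N)nc2ccc(F)cc12` keeps the ethylcarbamoyl group of compound 3 and makes a single change: pyridin-2-yl in place of phenyl on an aromatic carbon. The only measured step between two of these compounds is an at least 1.5-fold higher number from compound 2 to compound 3 (0.19 log units; that floor lies within the scatter). It places methyl in place of hydrogen on a saturated chain carbon bound to an amide-type nitrogen, so it does not touch the aromatic group now being exchanged. Compound 1 also carries pyridin-2-yl but has no ethylcarbamoyl group, so its value does not isolate this exchange. No measurement therefore gives the size of the swap itself. Among the measured compounds shown here, with an at least 1.5-fold higher number from compound 2 to compound 3 (0.19 log units; that floor lies within the scatter) as the sole measured step, and that at another place, no shift beyond the scatter is expected in this assay. The estimated change is a 1.2-fold lower number from compound 3 to compound 4 (0.06 log units; within the scatter), which is expected to stay within the scatter. Compound 4 is estimated at 19 mL.min-1.g-1, with an expected range of 11 mL.min-1.g-1 to 34 mL.min-1.g-1.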

Compound 4, intrinsic clearance in microsomes: < 14 mL.min-1.g-1
Compound 4: only a limit was reported; the forecaster's own chance of this, stated with the estimate: 25%; middle value at least 1.3-fold (0.13 log units) away from the limit.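

In this assay, pyridin-2-yl in place of phenyl on this aromatic carbon, ortho to an ethylcarbamoyl group, gives an at least 1.5-fold lower number from compound 3 to compound 4 (0.19 log units; that floor lies within the scatter), so the exchange brings no rise in the number, although the floor of the step does not by itself clear the scatter. Compound 4 gives < 14 mL.min-1.g-1, which is a limit of the assay and not a number. Among the compounds shown here, with pyridin-2-yl held at this position, ethylcarbamoyl in place of the second pyridin-2-yl gives an at least 3.3-fold lower number from compound 1 to compound 4 (0.52 log units; beyond the scatter), so pyridin-2-yl at this position does not on its own carry the higher number of compound 1, which the earlier compounds could not show.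

Going by these compounds, the full size of the exchange stays unknown, because the reading for compound 4 ends at the limit: the limit of < 14 mL.min-1.g-1 in this assay, at which 2 of the 4 values shown sit. Also open is how a pyridin-3-yl or pyrimidin-2-yl group on this aromatic carbon, or a propyl chain in place of the ethyl of the ethylcarbamoyl group, would read in this assay.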